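Chloro on the fused ring: compound 3 to compound 4

A few compounds are considered here, and "the series" means these few. Any claim that something is new, unique, unknown or untested is made for them only; others in the source may bear on it.

Measured so far in a functional assay on cells (Cancer cell lines, Homo sapiens) for cytotoxicity, read by sulforhodamine B assay, with a stated time of 48 h; a lower number here means a stronger inhibitor of growth, a higher number a weaker inhibitor of growth:
compound 1 `O=C1N=C(N2N=C(c3ccccc3)CC2c2ccccc2O)S/C1=C1/C(=O)Nc2ccccc21` gives 2030 nM
compound 2 `COc1ccc(C2CC(c3ccccc3)=NN2C2=NC(=O)/C(=C3\C(=O)Nc4ccccc43)S2)cc1` gives 2380 nM
compound 3 `COc1ccc(C2=NN(C3=NC(=O)/C(=C4\C(=O)Nc5ccccc54)S3)C(c3ccc(OC)cc3)C2)cc1` gives 88100 nM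

Compound 3 has the highest number of the three; the step of a 37-fold higher number from compound 2 to compound 3 (1.57 log units; beyond the scatter) is large, and compound 1 lies even further below it. Compound 4 `COc1ccc(C2=NN(C3=NC(=O)/C(=C4\C(=O)Nc5ccc(Cl)cc54)S3)C(c3ccc(OC)cc3)C2)cc1` differs from compound 3 by chloro in place of hydrogen on an aromatic carbon. For the measured compounds named here, no measured step touches that fused ring: a 1.2-fold higher number from compound 1 to compound 2 (0.07 log units; within the scatter) changes a group on a saturated ring carbon, and a 37-fold higher number from compound 2 to compound 3 (1.57 log units; beyond the scatter) changes a group on the other aryl ring. With nothing bearing on the site of the change, no step beyond the scatter is expected in this assay. Compound 4 is therefore estimated at 70000 nM, with a range of 15000 nM to 300000 nM. That estimate means a step of a 1.3-fold lower number from compound 3 to compound 4 (0.10 log units; within the scatter) is expected.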

Compound 4, concentration for 50% growth inhibition: 200 nM
Compound 4: middle estimate off by 350-fold (2.54 log units), on the high side; measured number outside the range, below it.
By their numbers in this assay, from the lowest: compound 4; then compounds 1 and 2 (each within the scatter of the next); then compound 3.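

In this assay, the fused ring turns out to be a highly responsive site: one chlorine atom on its aromatic carbon gives a 440-fold lower number from compound 3 to compound 4 (2.64 log units; beyond the scatter). This step runs in the opposite direction to a 37-fold higher number from compound 2 to compound 3 (1.57 log units; beyond the scatter), so the loss seen with compound 3 is not fixed across the shared core. Nothing available explains the size of this step.

From the compounds shown here alone, whether it is specific to chloro remains open; fluoro, methoxy or an amine at the same carbon would test this. Also open, going by these compounds, is whether chloro would act similarly in compound 1 and compound 2.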